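Chloro for methyl on a piperidine-linked phenyl ring

The compounds below may be only part of what the source reports. "The series", "measured", "known", "first", "only" and "open" are said of these compounds alone.

Measured compounds:
compound 1, `Cc1cccc(NC(=O)CN2CCN(c3cccc4ccccc34)CC2)c1`: 16.4%
compound 2, `Cc1ccc(C2CCN(CC(=O)Nc3cccc(C)c3)CC2)nc1`: "not active" (no number reported), no number
compound 3, `Cc1ccc(C2CCN(CC(=O)Nc3cccc(C)c3)CC2)cc1`: "not active" (no number reported), no number

The three measured compounds share an anilide and a saturated six-membered nitrogen ring, and differ in the aryl group attached to that ring. In an assay on cells for agonist activity at D(4) dopamine receptor (Homo sapiens), read by luminescence and beta-arrestin recruitment, with a stated time of 90 min (a lower number here means a smaller maximal response, a higher number a larger maximal response), compound 1 reaches 16.4%, a small maximal response. Compound 2 was reported as "not active" (no number reported) in this assay, with no number given. Compound 3 stands in the same place: in this assay compound 3 was reported as "not active" (no number reported), and no number exists for it. Going by the values given here, two of the three measured compounds thus give no measurable response, and the only numbered value is low.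

Compound 4, `Cc1cccc(NC(=O)CN2CCC(c3ccc(Cl)cc3)CC2)c1`, differs from compound 3 by a single change: chloro in place of methyl on an aromatic carbon. Among the compounds with values here, no step between measured compounds is available to size this change. Given that compound 3 produced no reported number in this assay, the expectation for compound 4 is a step of no more than the usual scatter, in no clear direction, and a real chance of again no numbered result.

Compound 4 is therefore estimated to give 10% in this assay, expected within 0% to 28%.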

Compound 4, largest response reached (Emax), in percent of the reference or control that the assay uses: "not active" (no number reported)
Compound 4 has no reported number here; there is nothing to compare the estimate with.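

Going by these compounds alone, compound 3 and compound 4 were both reported as not active in this assay, so no step from 4-methylphenyl to 4-chlorophenyl can be read between them. The compounds shown leave open whether this exchange changes the response at all. No supporting evidence bears on this result.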